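This account rests on a few compounds, and the source may have more. Where it says the series, first, only, none or still open, it means among the compounds named here.

In a functional assay on the whole organism (Hindlimb, strain albino) with Mus musculus as the target, in the maximal electroshock model, with a stated time of 0.5 h (on this read-out higher numbers stand for an effect only at larger amounts of compound and lower numbers for an effect already at smaller amounts), compound 2 (`CC(=O)N1N=C(Nc2nc3ccccc3s2)CC1c1ccccc1`) gives 315 umol/kg and lies within the scatter of compound 1 (`CC(=O)N1N=C(Nc2nc3ccc(Cl)cc3s2)CC1c1ccccc1`), which gives 161 umol/kg in the same test. With only these two numbers, the footing is thin. Compound 3 (`CC(=O)N1N=C(Nc2nc3ccccc3s2)CC1c1ccc(Cl)cc1`) differs from compound 2 in one place, where phenyl becomes 4-chlorophenyl: chloro in place of hydrogen on an aromatic carbon amounts to chloro in place of hydrogen on an aromatic carbon, para to a large group. Within the data shown here, one measured step bears on this, a swap between chloro and hydrogen elsewhere in the molecule, and it gave a 2.0-fold higher number from compound 1 to compound 2 (0.29 log units; within the scatter) as its result. That change sits at a different place, so it is only a loose guide, and no step beyond the scatter is expected in this assay here. The estimate is a 1.4-fold lower number from compound 2 to compound 3 (0.14 log units; within the scatter) as the expected step. Compound 3 is expected at 230 umol/kg with an estimated range from 100 umol/kg to 500 umol/kg for the measurement.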

Compound 3, dose for half-maximal effect: 209 umol/kg
Estimate against measurement, compound 3: 1.1-fold (0.04 log units) above; low and high end bracket the measured number.
By their numbers in this assay, from the lowest: compounds 1, 3 and 2 (each within the scatter of the next).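

Among these compounds, the step from hydrogen to chloro on the phenyl ring, a 1.5-fold lower number from compound 2 to compound 3 (0.18 log units; within the scatter) in this assay, is the first reading at this position, since the earlier pair carried its chloro elsewhere in the molecule. It shows that 4-chlorophenyl can take the place of phenyl without moving the number beyond the scatter, and the other chloro swap, with a 2.0-fold higher number from compound 1 to compound 2 (0.29 log units; within the scatter) as its result, did the same. Nothing available here offers an explanation for this result.

From the compounds shown here alone, whether a clearly different group at this position, such as a methoxy group, an amine or a carboxylic acid, would move the number beyond the scatter remains open. So does the effect of placing chloro elsewhere on the phenyl ring.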